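This account rests on a few compounds, and the source may have more. Where it says the series, first, only, none or still open, it means among the compounds named here.

Measured so far in an ADME assay on A549 cells (Homo sapiens) for cytotoxicity, read by MTT assay, with a stated time of 4 days; a higher number here means a weaker inhibitor, a lower number a stronger inhibitor:
- Compound 1 `COc1cc(C[C@H]2C(=O)OC[C@@H]2Cc2ccc(OC)c(OC)c2)ccc1NC(C)=O`: > 50000 nM, a limit.
- Compound 2 `CCC(=O)Nc1ccc(C[C@H]2C(=O)OC[C@@H]2Cc2ccc(OC)c(OC)c2)cc1OC`: > 50000 nM, a limit.
- Compound 3 `COc1cc(C[C@H]2C(=O)OC[C@@H]2Cc2ccc(OC)c(OC)c2)ccc1Nc1ccc([N+](=O)[O-])cc1`: > 50000 nM, a limit.

Compound 1 has no number on this scale, only a limit, and it is not alone there: the record shows (the limit of > 50000 nM in this assay, at which 3 of the 3 values shown sit). The next compound, compound 4 `COc1cc(C[C@H]2C(=O)OC[C@@H]2Cc2ccc(OC)c(OC)c2)ccc1Nc1ccc(F)cc1`, keeps the core of compound 1 and changes only the group on the nitrogen: 4-fluorophenyl in place of acetyl on a nitrogen on an aromatic ring. In short, this places 4-fluorophenyl in place of acetyl on a nitrogen on an aromatic ring.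

The closest measured change is a step that the two limits leave unreadable from compound 1 to compound 3, in which 4-nitrophenyl replaces acetyl at that nitrogen. The change a step that the two limits leave unreadable from compound 2 to compound 3 brings in the same group in place of propanoyl. The third, a step that the two limits leave unreadable from compound 1 to compound 2, concerns only the acyl chain and bears on this change less directly. None of these gives a size, so the expectation rests on limits alone.

The nearest relative of compound 4 is compound 3, and compound 3 gives > 50000 nM, which is again a limit. No clear shift in this assay is therefore expected, and no direction can be argued. The expected step is a number no higher from compound 1 to compound 4 (the limit leaves the size open). The estimate for compound 4 is 50000 nM, with an expected range from 20000 nM to 100000 nM.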

Compound 4, half-maximal inhibitory concentration: > 50000 nM
Compound 4: a limit, no number; the forecaster's own chance of this, stated with the estimate: 75%; the middle value lies on the limit itself.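

Compound 4 has only a limit, so the steps to it from compound 1, compound 2 and compound 3 cannot be read, and all four compounds stand together: the limit of > 50000 nM in this assay, at which 4 of the 4 values shown sit. The compounds shown leave open whether any change at that nitrogen moves the read-out in this assay at all, and by how much.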